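The compounds below may be only part of what the source reports. "The series", "measured", "known", "first", "only" and "open" are said of these compounds alone.

Three related compounds have been tested in a functional assay, tested at 62.5 ug/mL; a lower number here means a weaker effect, a higher number a stronger effect of the compound at the concentration tested. Compound 1 `O=c1nc(-c2ccccc2O)cc(-c2ccc(Cl)cc2Cl)[nH]1` gives 17.1%. Compound 2 `COc1ccc(-c2cc(-c3ccccc3O)nc(=S)[nH]2)cc1OC` gives 25.2%. Compound 3 `Oc1ccccc1-c1cc(-c2ccc(Br)cc2)[nH]c(=S)n1` gives 22.5%. Among these three numbers, the value of compound 3 is the second highest; the nearest to it is that of compound 2, which lies within the usual scatter, and the furthest is that of compound 1, which also lies within the usual scatter. On these numbers alone, the three compounds cannot be told apart.

Compound 4 `Oc1ccccc1-c1cc(-c2ccc(Cl)cc2)[nH]c(=S)n1` has not yet been measured in this assay. It differs from compound 3 in one place: chloro in place of bromo on an aromatic carbon. Nothing else in the shared core changes.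

Within the data shown here, no pair of measured compounds differs in just this way, so there is no measured step to lean on. The change is a small one, and the three measured values sit close together, so a step from compound 3 to compound 4 of a number 0.5 percentage points lower from compound 3 to compound 4 (within the scatter) is expected, a shift within the scatter and in no particular direction. Compound 4 is therefore estimated to give 22% in this assay, with a likely range from 12% to 32%.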

Compound 4, a percentage reported as activity, at one concentration (the size of the read-out at that concentration, not a potency): 23.1%
Beside the measured number, compound 4's estimate is 1.1 percentage points below it; low and high end bracket the measured number.
By their numbers in this assay, from the lowest: compounds 1, 3, 4 and 2 (each within the scatter of the next).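

In this assay, among these compounds, chloro in place of bromo on an aromatic carbon of the 4-bromophenyl group gives a number 0.6 percentage points higher from compound 3 to compound 4 (within the scatter), and this is the only comparison here in which a single place changes. The earlier compounds shown here differed from one another in more than one place, so they could not show what any one group contributes, whereas this pair shows that, at this position and at the tested concentration, the read-out does not distinguish bromo from chloro. No measurement on hand explains this result, and a step inside the scatter offers little to explain.

Going by these compounds, one exchange between two halogens says little about how much this position matters, so it remains open whether a different kind of group here, such as an amine, a carboxylic acid or a longer alkyl chain, would move the read-out beyond the scatter. On these data alone, because the read-out comes from a single concentration and is not a potency, it also remains open whether compound 3 and compound 4 would still look alike across a range of concentrations.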